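Adding a Methoxy Group to Compound 1

This account rests on a few compounds, and the source may have more. Where it says the series, first, only, none or still open, it means among the compounds named here.

In a functional assay on A549 cells (Homo sapiens) for cytotoxicity, with a stated time of 3 days (on this read-out higher numbers stand for weaker inhibition of growth and lower numbers for stronger inhibition of growth), compound 1 `O=C(/C=C/c1ccccn1)c1ccc(N2CCN(Cc3cc(C(=O)/C=C/c4ccccn4)ccc3O)CC2)cc1` gives 1080 nM, the lowest of the two numbers shown; its nearest neighbour is compound 3 `COc1cc(C(=O)/C=C/c2cccnc2)cc(CN2CCN(c3ccc(C(C)=O)cc3)CC2)c1O` at 9770 nM, a gap beyond the scatter. Compound 2 `O=C(/C=C/c1cccs1)c1ccc(N2CCN(Cc3cc(C(=O)/C=C/c4cccs4)ccc3O)CC2)cc1` reaches only a limit of the assay, > 37000 nM; this is the limit of > 37000 nM in this assay, at which 1 of the 3 values shown sits. Compound 4 `COc1cc(C(=O)/C=C/c2ccccn2)cc(CN2CCN(c3ccc(C(=O)/C=C/c4ccccn4)cc3)CC2)c1O` differs from compound 1 by methoxy in place of hydrogen on an aromatic carbon. Among the measured compounds shown here, no measured pair isolates this change: compound 3 carries the methoxy but differs from compound 1 in further places, so its number gives no clean step. The expected step in this assay, a 1.5-fold higher number from compound 1 to compound 4 (0.17 log units; within the scatter), is small, within the scatter or slightly weaker. Compound 4 is therefore estimated at 1600 nM, between 500 nM and 5500 nM.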

Compound 4, concentration for 50% growth inhibition: 1000 nM
Estimate against measurement, compound 4: 1.6-fold (0.20 log units) above; measured number inside the range.
By their numbers in this assay, from the lowest: compounds 4 and 1 (each within the scatter of the next); then compound 3. At a limit, above all of these: compound 2.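

Among the compounds shown here, the methoxy on the aromatic carbon ortho to a hydroxy group gives a 1.1-fold lower number from compound 1 to compound 4 (0.03 log units; within the scatter) in this assay, the first step that isolates this change. At this position on the core of compound 1, methoxy in place of hydrogen therefore leaves the read-out within the scatter, which compound 3, differing from compound 1 in further places, could not show. Nothing given here accounts for this result. The compounds shown leave open whether an ethoxy group or an amine at this position would do the same. They also leave open whether the methoxy result holds with a methyl ether in place of the hydroxy group.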